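The source may hold more compounds than are shown below. What is called first, only, known or untested is meant among the compounds shown, and "the series" means these compounds.

Among the compounds with values here, in a functional assay on HL-60 cells (Homo sapiens) for antiproliferative activity, with a stated time of 72 h (a lower number here means a stronger inhibitor of growth, a higher number a weaker inhibitor of growth), compound 2, `C=C(CCC)C(=O)c1ccc(OCC(=O)O)c(C)c1C`, gives 19300 nM, the higher of the two numbers so far, while compound 1, `C=C(CCC)C(=O)c1ccc(OC(C)C(=O)OC)c(C)c1C`, gives 5600 nM. Compound 3, `C=C(CCC)C(=O)c1ccc(OCC(=O)OC)c(C)c1C`, has methyl in place of hydrogen on an oxygen next to a carbonyl group, so carboxymethyl becomes (methoxycarbonyl)methyl: methyl in place of hydrogen on an oxygen next to a carbonyl group. Within the data shown here, one measured step bears on this: a 3.4-fold higher number from compound 1 to compound 2 (0.54 log units; beyond the scatter), a modest change beyond the scatter, with carboxymethyl in place of 1-(methoxycarbonyl)ethyl. That step is only a partial guide, since the group in compound 3 is (methoxycarbonyl)methyl and not 1-(methoxycarbonyl)ethyl. Read in reverse, it points to a lower number of similar, modest size in this assay. The expected change is a 3.0-fold lower number from compound 2 to compound 3 (0.47 log units; beyond the scatter). Compound 3 is estimated at 6500 nM, with an expected range of 2500 nM to 15000 nM.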

Compound 3, concentration for 50% growth inhibition: 8600 nM
Compound 3: the middle estimate sits 1.3-fold (0.12 log units) below what was measured, within the range that was stated.
By their numbers in this assay, from the lowest: compounds 1 and 3 (each within the scatter of the next); then compound 2.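

In this assay, methyl in place of hydrogen on an oxygen next to a carbonyl group, read as carboxy to methoxycarbonyl, gives a 2.2-fold lower number from compound 2 to compound 3 (0.35 log units; beyond the scatter) and isolates this change at a single place. Hydrogen in place of methyl on a saturated chain carbon bound to a carbonyl carbon and an oxygen on an aromatic ring gives a 1.5-fold higher number from compound 1 to compound 3 (0.19 log units; within the scatter), so that chain methyl makes no readable difference between these two methyl esters, and the combined step a 3.4-fold higher number from compound 1 to compound 2 (0.54 log units; beyond the scatter) is not a measure of the acid-to-ester change alone. No measurement bearing on the origin of these steps is available here.

Open, going by these compounds, is whether an amide or an ethyl ester in place of methoxycarbonyl stays close to compound 3 at 8600 nM in this assay. Also open, on these data alone, is whether the chain methyl stays without readable effect when a carboxylic acid stands in place of the methyl ester.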